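A few compounds are considered here, and "the series" means these few. Any claim that something is new, unique, unknown or untested is made for them only; others in the source may bear on it.

Measured so far:

Compound 1 `COc1cc(C(C)(C)C)ccc1C/N=C(\S)NCc1ccc(NS(C)(=O)=O)cc1` – 2400 nM
Compound 2 `COCCOc1cc(C(C)(C)C)ccc1C/N=C(\S)NCc1ccc(NS(C)(=O)=O)cc1` – 60 nM

In a functional assay for inhibition of Vanilloid receptor (Rattus norvegicus) (a lower number here means a stronger inhibitor, a higher number a weaker inhibitor), compound 2 holds the lower of the two numbers; its nearest neighbour, compound 1, sits at 2400 nM, and the step of a 40-fold lower number from compound 1 to compound 2 (1.60 log units; beyond the scatter) is the only one seen. Compound 3 `CC(=O)OCc1cc(C(C)(C)C)ccc1C/N=C(\S)NCc1ccc(NS(C)(=O)=O)cc1` differs from compound 2 by acetoxymethyl in place of 2-methoxyethoxy on an aromatic carbon. The same position has already proved decisive: growing a methoxy into a 2-methoxyethoxy brought the large gain from compound 1 to compound 2. Among the measured compounds shown here, the new acetoxymethyl group has the same number of heavy atoms and the same count of hydrogen-bond acceptors, but a different arrangement, and no measured step tells how this assay answers to it. Compound 3 is therefore expected to lose part of that gain, landing between the two measured values, with an estimated step of an 8.3-fold higher number from compound 2 to compound 3 (0.92 log units; beyond the scatter). The estimate for compound 3 is 500 nM, within a range of 100 nM to 3000 nM.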

Compound 3, half-maximal inhibitory concentration: 580 nM
Estimate against measurement, compound 3: 1.2-fold (0.06 log units) below; measured number inside the range.
By their numbers in this assay, from the lowest: compound 2; then compound 3; then compound 1.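

In this assay, the change of 2-methoxyethoxy to acetoxymethyl gives a 9.7-fold higher number from compound 2 to compound 3 (0.99 log units; beyond the scatter) even though both groups have the same count of heavy atoms and of hydrogen-bond acceptors, so at this position those counts alone do not set the number. Acetoxymethyl still keeps part of the gain over methoxy, with a 4.1-fold lower number from compound 1 to compound 3 (0.62 log units; beyond the scatter) as its step, which means that 2-methoxyethoxy is not the only group here that improves on methoxy. Nothing available explains why two groups with matching counts differ this much.

As far as these compounds go, it remains open whether the difference follows the carbonyl of acetoxymethyl or the chain of 2-methoxyethoxy. How this position would answer to an amine, a carboxylic acid or a longer ether chain also remains an open question.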